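A Dimethylphenyl Isomer and Its Expected Cytotoxicity

The compounds below may be only part of what the source reports. "The series", "measured", "known", "first", "only" and "open" are said of these compounds alone.

Compound 1 `Cc1ccc(C)c(-c2nc(CN3CCC(C(=O)NCCCN4C[C@H](C)C[C@H](C)C4)CC3)c(C)o2)c1`: 4070 nM
Compound 2 `Cc1ccccc1-c1nc(CN2CCC(C(=O)NCCCN3CCCC(C(C)C)C3)CC2)c(C)o1`: 5820 nM
Compound 3 `Cc1ccccc1-c1nc(CN2CCC(C(=O)N3CCN(CCN(C)C)CC3)CC2)c(C)o1`: 27200 nM

In an ADME assay on Huh7.5.1 cells (Homo sapiens) for cytotoxicity, read by ATP content, with a stated time of 48 h (on this read-out lower numbers stand for higher toxicity in this test and higher numbers for lower toxicity in this test), compound 1 gives 4070 nM, the lowest of the three numbers shown. Compound 2 gives 5820 nM in this assay, a value within the usual scatter of that of compound 1. Compound 3 gives 27200 nM, a gap to compound 1 that lies beyond the scatter. Among the compounds with values here, no pair of measured compounds differs in a single place, so no step has been measured.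

Compound 4 `Cc1ccc(-c2nc(CN3CCC(C(=O)NCCCN4C[C@H](C)C[C@H](C)C4)CC3)c(C)o2)c(C)c1` differs from compound 1 in one place: 2,4-dimethylphenyl in place of 2,5-dimethylphenyl on an aromatic carbon. Because compound 1 gives 4070 nM and nothing measured shows the effect of rearranging the methyls, the step of a 1.1-fold higher number from compound 1 to compound 4 (0.04 log units; within the scatter) is expected to fall within the scatter, in no clear direction. Compound 4 is estimated at 4500 nM, between 2000 nM and 10000 nM.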

Compound 4, half-maximal cytotoxic concentration: 4110 nM
Beside the measured number, compound 4's estimate is 1.1-fold (0.04 log units) above it; the measured number falls inside the stated range.
By their numbers in this assay, from the lowest: compounds 1, 4 and 2 (each within the scatter of the next); then compound 3.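

In this assay, the first step measured in this set, a 1.0-fold higher number from compound 1 to compound 4 (0.00 log units; within the scatter), replaces 2,5-dimethylphenyl with 2,4-dimethylphenyl on an aromatic carbon of the five-membered ring. At this position, then, the read-out does not separate the two dimethylphenyl isomers, at least with this side chain. Nothing available explains this result. 

Going by these compounds, it remains open whether a more different group here, such as a chlorophenyl or a pyridine ring, would shift the number beyond the scatter. On these data alone, the same isomer swap also remains open on a different side chain, such as the dimethylaminoethyl piperazine amide of compound 3.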